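Methoxy added to the pyridine of the neopentyl amide analogue

This account rests on a few compounds, and the source may have more. Where it says the series, first, only, none or still open, it means among the compounds named here.

Compound 2 `Cc1cc(C)c(C(=O)N[C@@H](CNC(=O)CO[C@@H]2C[C@@H](CNc3ccccn3)N(C(=O)CC(C)(C)C)C2)C(=O)O)c(C)c1` has the higher of the two numbers in an assay on a protein complex for inhibition of integrin alpha-5/beta-1 (Homo sapiens), read by ELISA (a higher number here means a weaker inhibitor, a lower number a stronger inhibitor), with 1.6 nM, while compound 1 `COc1ccnc(NC[C@@H]2C[C@@H](OCC(=O)NC[C@H](NC(=O)c3c(C)cc(C)cc3C)C(=O)O)CN2C(=O)OCc2ccccc2)c1` gives 0.54 nM; these two differ in more than one place, so the gap between them cannot be pinned to a single change. Compound 3 `COc1ccnc(NC[C@@H]2C[C@@H](OCC(=O)NC[C@H](NC(=O)c3c(C)cc(C)cc3C)C(=O)O)CN2C(=O)CC(C)(C)C)c1` carries the change methoxy in place of hydrogen on an aromatic carbon on the core of compound 2, methoxy in place of hydrogen on an aromatic carbon. Since compound 1, which also carries this methoxy, gives 0.54 nM, a modest downward step a 1.8-fold lower number from compound 2 to compound 3 (0.25 log units; within the scatter) is expected, possibly still within the scatter. Compound 3 is estimated at 0.9 nM, in the range 0.4 nM to 2.5 nM.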

Compound 3, half-maximal inhibitory concentration: 0.55 nM
For compound 3 the middle estimate is 1.6-fold (0.21 log units) above the measured one, and the stated range covers the measured number.
By their numbers in this assay, from the lowest: compounds 1 and 3 (each within the scatter of the next); then compound 2.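

In this assay, within the data shown here, methoxy opposite the ring nitrogen gives a 2.9-fold lower number from compound 2 to compound 3 (0.46 log units; beyond the scatter), the first single-change reading at this position, and it lies beyond the scatter. With that methoxy present, neopentyl in place of benzyloxy on the carbonyl carbon gives a 1.0-fold higher number from compound 1 to compound 3 (0.01 log units; within the scatter), so the two groups are not told apart in this assay. No available measurement bears on the origin of either step.

As far as these compounds go, whether ethoxy, dimethylamino or fluorine opposite the ring nitrogen would match methoxy remains open. So does whether the methoxy step carries over when benzyloxy sits on the carbonyl carbon.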